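The source may report more compounds than this note shows. Statements on the series, on what has been measured and on what is new or still open speak of the compounds shown alone.

Compound 1 `COc1cc(/C=C2\CN(C)C/C(=C\c3ccc(Br)cc3)C2=O)cc(OC)c1` sets the first reference point: in an ADME assay on L02 cells (Homo sapiens) for cytotoxicity, read by MTT assay, with a stated time of 24 h (a lower number here means a stronger inhibitor, a higher number a weaker inhibitor), compound 1 gives 21300 nM. Compound 2 `COc1cc(/C=C2\CN(C)C/C(=C\c3ccc(Cl)cc3Cl)C2=O)cc(OC)c1` carries one change, (2,4-dichlorophenyl in place of 4-bromophenyl on a double-bonded chain carbon bound to a double-bonded ring carbon), and in this assay compound 2 gives 18800 nM, so that a 1.1-fold lower number from compound 1 to compound 2 (0.05 log units; within the scatter). Compound 3 `CN1C/C(=C\c2ccc(Br)cc2)C(=O)/C(=C/c2cccc([N+](=O)[O-])c2)C1` has a different core; how its core differs from that of compound 1 is not broken down here. In this assay compound 3 gives 9850 nM, a lower number than compound 1 shows, while its number and that of compound 2 lie within the scatter of each other. Compound 4 `CN1C/C(=C\c2cccc([N+](=O)[O-])c2)C(=O)/C(=C/c2ccc(Cl)cc2Cl)C1` is not yet measured. It differs from compound 3 by 2,4-dichlorophenyl in place of 4-bromophenyl on a double-bonded chain carbon bound to a double-bonded ring carbon, the same change that led from compound 1 to compound 2. Because a 1.1-fold lower number from compound 1 to compound 2 (0.05 log units; within the scatter) stayed within the scatter, the step expected is a 1.1-fold lower number from compound 3 to compound 4 (0.04 log units; within the scatter). Compound 4 is therefore estimated at 9000 nM, likely between 4500 nM and 18000 nM.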

Compound 4, half-maximal inhibitory concentration: 14000 nM
Compound 4: the middle estimate sits 1.6-fold (0.19 log units) below what was measured; measured number inside the range.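

Putting 2,4-dichlorophenyl in place of 4-bromophenyl on the core of compound 3 gives, in this assay, a 1.4-fold higher number from compound 3 to compound 4 (0.15 log units; within the scatter). Set beside the same change on the core of compound 1, the two steps cannot be told apart: the same change on two cores in this assay, a 1.1-fold lower number (0.05 log units; within the scatter) from compound 1 to compound 2 and a 1.4-fold higher number (0.15 log units; within the scatter) from compound 3 to compound 4, 1.6-fold (0.21 log units) apart, within the scatter of two such steps. On these two cores the change therefore stays a small step, but two pairs set no rule for other cores and do not show that the change has a real effect or none at all.

From the compounds shown here alone, it remains open whether a phenyl ring carrying an amine or a carboxylic acid, in place of 4-bromophenyl, would shift the number in this assay. Also open, going by these compounds, is how the same change behaves on any further core.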